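The source may hold more compounds than are shown below. What is called first, only, known or untested is meant among the compounds shown, and "the series" means these compounds.

Three members of the series carry numbers in a functional assay on aorta (Rattus norvegicus, strain Wister); a lower number here means a stronger inhibitor, a higher number a weaker inhibitor. Compound 1 `COc1nc(-c2nc3ccccc3[nH]2)cc(-c2ccc(Cl)cc2)c1C#N` gives 286000 nM. Compound 2 `COc1nc(-c2nc3ccccc3n2C)cc(-c2ccc(Cl)cc2)c1C#N` gives 145000 nM, the lowest of the three numbers, with a 2.0-fold lower number from compound 1 to compound 2 (0.29 log units; within the scatter). Compound 3 `CCOc1nc(-c2nc3ccccc3n2C)cc(-c2ccc(Cl)cc2)c1C#N` gives 293000 nM, and a 2.0-fold higher number from compound 2 to compound 3 (0.31 log units; beyond the scatter). Compound 4 `COc1nc(-c2nc3ccccc3n2C)cc(-c2ccc(F)cc2)c1C#N` is not yet measured; it differs from compound 2 by fluoro in place of chloro on an aromatic carbon, read one bond further out as 4-chlorophenyl to 4-fluorophenyl. Neither measured step touches that ring: the step from compound 1 to compound 2 altered the aromatic nitrogen, the step from compound 2 to compound 3 the chain on the ring oxygen, both of modest size. With no direct guide, a modest step in either direction, or none beyond the scatter, is expected in this assay. The expected step is a 1.5-fold higher number from compound 2 to compound 4 (0.18 log units; within the scatter). Compound 4 is estimated at 220000 nM, range 80000 nM to 600000 nM.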

Compound 4, half-maximal inhibitory concentration: 343000 nM
Compound 4: middle estimate off by 1.6-fold (0.19 log units), on the low side, and the stated range covers the measured number.
By their numbers in this assay, from the lowest: compounds 2, 1, 3 and 4 (each within the scatter of the next, the first and the last beyond it).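

Fluoro in place of chloro on the aromatic carbon para to a large group gives a 2.4-fold higher number from compound 2 to compound 4 (0.37 log units; beyond the scatter) in this assay and shows that this ring position, untouched by the earlier steps, affects the read-out. Within this single pair, chloro gives the lower number, so the 4-chlorophenyl compound 2 stays lowest of the series. Nothing available explains the step.

A single halogen swap does not set a trend, and bromo, methoxy or an amine at this position could still move the number either way. On these data alone, whether the same swap holds on the ethoxy compound 3 also remains open.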